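Urea in place of amide on the shared core

The source may report more compounds than this note shows. Statements on the series, on what has been measured and on what is new or still open speak of the compounds shown alone.

Of the compounds shown here, three of the shared core have been measured in a functional assay on COLO 205 cells (Homo sapiens) for inhibition, read by sulforhodamine B assay, with a stated time of 48 h; a higher number here means a weaker inhibitor of growth, a lower number a stronger inhibitor of growth. Compound 1 `O=C(Nc1cccc(-n2cc(-c3ccncc3)c(-c3ccc(Cl)c(O)c3)n2)c1)Nc1ccc(Cl)c(Cl)c1` gives 9490 nM in this assay. Compound 3 `O=C(Nc1cccc(-n2cc(-c3ccncc3)c(-c3ccc(Cl)c(O)c3)n2)c1)Nc1cc(C(F)(F)F)cc(C(F)(F)F)c1`, which also carries a urea, gives 1580 nM. Compound 2 `COc1cc(-c2nn(-c3cccc(NC(=O)c4cccc(C(F)(F)F)c4)c3)cc2-c2ccncc2)ccc1Cl`, which carries an amide instead, gives 5170 nM in this assay and stands second highest of the three numbers; its gap to compound 1 lies within the scatter, while its gap to compound 3 lies beyond it. Nothing further can be said of order between compound 1 and compound 2.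

Compound 4 `COc1cc(-c2nn(-c3cccc(NC(=O)Nc4ccc(Cl)c(C(F)(F)F)c4)c3)cc2-c2ccncc2)ccc1Cl` has not yet been measured in this assay. It differs from compound 2 in one place: (4-chloro-3-(trifluoromethyl)phenyl)amino in place of 3-(trifluoromethyl)phenyl on a carbonyl carbon. Among the measured compounds shown here, no step between measured compounds covers this change, so the only guide is that the two measured ureas, compound 1 and compound 3, sit on either side of compound 2 in this assay, one within and one beyond the scatter. A modest step downward is therefore expected, of a size that may or may not pass beyond the scatter. The step is estimated at a 1.7-fold lower number from compound 2 to compound 4 (0.24 log units; within the scatter). Compound 4 is expected to give 3000 nM in this assay, with a range from 1000 nM to 12000 nM.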

Compound 4, concentration for total growth inhibition: 1540 nM
Estimate against measurement, compound 4: 1.9-fold (0.29 log units) above; low and high end bracket the measured number.
By their numbers in this assay, from the lowest: compounds 4 and 3 (each within the scatter of the next); then compounds 2 and 1 (each within the scatter of the next).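

Among the compounds shown here, this is the first step that isolates one place: on a carbonyl carbon whose other neighbour is an amide-type nitrogen, (4-chloro-3-(trifluoromethyl)phenyl)amino in place of 3-(trifluoromethyl)phenyl gives a 3.4-fold lower number from compound 2 to compound 4 (0.53 log units; beyond the scatter) in this assay as a single readable change. For the compounds shown here, the earlier urea and amide compounds differed in more than one place and gave no such step, whereas this pair shows that the number responds to a change at this carbonyl carbon by more than the scatter. Nothing at hand bears on why the number falls.

The step carries two changes at once, the amino nitrogen and the 4-chloro group, and the compounds shown hold neither (3-(trifluoromethyl)phenyl)amino nor 4-chloro-3-(trifluoromethyl)phenyl on this carbonyl carbon, so the share of each remains open. Also open, on these data alone, is how the number would respond to a group of another kind on this carbonyl carbon, such as a piperidine or a short alkyl chain in place of the aromatic ring.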